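Aryl swap on the triazole: compound 3 to compound 4

The compounds below may be only part of what the source reports. "The series", "measured", "known", "first", "only" and "open" are said of these compounds alone.

compound 1 `C/C(=C\CC/C(C)=C/CC[C@@H]1[C@@]2(C)CCC(=O)C(C)(C)[C@H]2CC[C@@]1(C)O)CC/C=C(\C)C(=O)OCc1cn(-c2ccccc2)nn1` — > 150000 nM
compound 2 `C/C(=C\CC/C(C)=C/CC[C@@H]1[C@@]2(C)CCC(=O)C(C)(C)[C@H]2CC[C@@]1(C)O)CC/C=C(\C)C(=O)OCc1cn(-c2ccc(C(C)(C)C)cc2)nn1` — 65800 nM
compound 3 `C/C(=C\CC/C(C)=C/CC[C@@H]1[C@@]2(C)CCC(=O)C(C)(C)[C@H]2CC[C@@]1(C)O)CC/C=C(\C)C(=O)OCc1cn(-c2ccc(Cl)cc2)nn1` — > 150000 nM

In an ADME assay on L132 cells (Homo sapiens) for cytotoxicity, read by MTT assay, with a stated time of 48 h (a higher number here means a weaker inhibitor, a lower number a stronger inhibitor), compound 1 reaches only the assay limit, > 150000 nM. Compound 2 gives a number in this assay, 65800 nM, and an at least 2.2-fold lower number from compound 1 to compound 2 (0.35 log units; beyond the scatter). Compound 3 again stops at the limit, > 150000 nM, so only a bound is known for it. Between the two, an at least 2.2-fold higher number from compound 2 to compound 3 (0.35 log units; beyond the scatter), whereas a step that the two limits leave unreadable from compound 1 to compound 3. Two of the three values thus sit at the limit of > 150000 nM in this assay, at which 2 of the 3 values shown sit.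

Compound 4 `C/C(=C\CC/C(C)=C/CC[C@@H]1[C@@]2(C)CCC(=O)C(C)(C)[C@H]2CC[C@@]1(C)O)CC/C=C(\C)C(=O)OCc1cn(-c2cccc(Br)c2)nn1` differs from compound 3 by 3-bromophenyl in place of 4-chlorophenyl on an aromatic nitrogen. Among the measured compounds shown here, the bearing steps are the one to compound 3 from compound 2 and the unreadable one from compound 1; a halogen on the phenyl has not moved the number off the limit. Compound 4 is therefore expected to stay near that limit, with a number no higher from compound 3 to compound 4 (the limit leaves the size open) as the expected step. The estimate for compound 4 is 150000 nM, in the range 60000 nM to 300000 nM.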

Compound 4, half-maximal inhibitory concentration: > 150000 nM
Compound 4: only a limit was reported; the forecaster's own chance of this, stated with the estimate: 60%; the middle value sits exactly at the limit.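

Replacing 4-chlorophenyl with 3-bromophenyl changes both the halogen and its ring position, yet compound 4 also gives only an assay limit in this assay, so the steps among compound 1, compound 3 and compound 4 cannot be read. The 4-(tert-butyl)phenyl of compound 2 remains the exception, with an at least 2.2-fold higher number from compound 2 to compound 4 (0.35 log units; beyond the scatter). The aryl groups shown mostly end at one ceiling: the limit of > 150000 nM in this assay, at which 3 of the 4 values shown sit.

Going by these compounds, whether an amine or a longer alkyl chain on the phenyl would also give a readable number remains open. Any difference between the two halogenated aryl groups also stays hidden behind the limit.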